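Ring-nitrogen substituent swaps in the shared core

The source may hold more compounds than are shown below. What is called first, only, known or untested is meant among the compounds shown, and "the series" means these compounds.

Compound 1 `Cc1nc(S(C)(=O)=O)ccc1Oc1ncnc(OC2CCN(C(=O)O[C@H](C)C(F)(F)F)CC2)c1F` is the reference of the pair: in a functional assay on isolated protein for inhibition of Glucose-dependent insulinotropic receptor (Homo sapiens), read by HTRF and cAMP accumulation (on this read-out lower numbers stand for an effect already at smaller amounts and higher numbers for an effect only at larger amounts of compound), compound 1 gives 9.2 nM. Going by the values given here, compound 2 `Cc1nc(S(C)(=O)=O)ccc1Oc1ncnc(OC2CCN(C(=S)OC(C)C)CC2)c1F` carries a different group on the ring nitrogen and, in this assay, compound 2 gives 69.9 nM, the highest number of the two measured; the only step recorded is a 7.6-fold higher number from compound 1 to compound 2 (0.88 log units; beyond the scatter), which shows how strongly this position answers to a change of substituent. Compound 3 `Cc1nc(S(C)(=O)=O)ccc1Oc1ncnc(OC2CCN(C(=O)C(F)(F)F)CC2)c1F` is not yet measured; it differs from compound 2 by a group of 6 heavy atoms (2 carbon, 1 oxygen, 3 fluorine; no ring) in place of a group of 6 heavy atoms (4 carbon, 1 oxygen, 1 sulfur; no ring), on an amine nitrogen in a ring. The step from compound 1 to compound 2 is the one that bears on it: a change at the same nitrogen moved the number by a modest amount beyond the scatter. Since compound 3 returns a fluorinated group at that place, a number nearer to that of compound 1 is expected, with a 3.5-fold lower number from compound 2 to compound 3 (0.54 log units; beyond the scatter) as the expected step. For compound 3 in this assay the estimate is 20 nM, within 6 nM to 70 nM.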

Compound 3, half-maximal effective concentration: 151 nM
Compound 3: middle estimate off by 7.6-fold (0.88 log units), on the low side, outside the stated range (above it).
By their numbers in this assay, from the lowest: compound 1; then compound 2; then compound 3.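

In this assay, fluorine in the group on the ring nitrogen does not by itself keep the number low: there is a 2.2-fold higher number from compound 2 to compound 3 (0.33 log units; beyond the scatter) when (trifluoromethyl)carbonyl replaces the fluorine-free group. The carbonyl carbon also answers strongly to what it carries, with a 16-fold higher number from compound 1 to compound 3 (1.22 log units; beyond the scatter) as trifluoromethyl replaces 1-(trifluoromethyl)ethoxy, the widest step among the three compounds. No measurement bears on the cause of either step.

As far as these compounds go, how an isopropoxycarbonyl group would stand on the same nitrogen remains open, and it would separate the sulfur of compound 2 from the fluorines of compound 1. An acetyl group would likewise show whether the trifluoromethyl of compound 3 matters on the carbonyl carbon at all.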